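The source may hold more compounds than are shown below. What is called first, only, known or untested is meant among the compounds shown, and "the series" means these compounds.

Three compounds share one core and differ only in the group attached to a saturated chain carbon bound to an amine nitrogen in a ring. In an assay on COS-7 cells for displacement of a labelled ligand from 5-hydroxytryptamine receptor 4 (Homo sapiens), read by scintillation counting, with a stated time of 30 min (a higher number here means a weaker inhibitor, a lower number a stronger inhibitor), compound 1 `COc1cc(N)c(Cl)cc1C(=O)N[C@H]1CCN(CCCn2cncn2)C[C@H]1OC` gives 1270 nM, compound 2 `CCOC(=O)N1CCC(CN2CC[C@H](NC(=O)c3cc(Cl)c(N)cc3OC)[C@H](OC)C2)CC1` gives 377 nM, and compound 3 `COc1cc(N)c(Cl)cc1C(=O)N[C@H]1CCN(CC2CCN(C(C)=O)CC2)C[C@H]1OC` gives 592 nM. Compound 3 thus stands second highest of the three, close to compound 2 and separated from compound 1 by a 2.1-fold lower number from compound 1 to compound 3 (0.33 log units; beyond the scatter). Compound 4 `CCC(=O)N1CCC(CCN2CC[C@H](NC(=O)c3cc(Cl)c(N)cc3OC)[C@H](OC)C2)CC1` carries (1-propanoylpiperidin-4-yl)methyl in place of 1-acetylpiperidin-4-yl on a saturated chain carbon bound to an amine nitrogen in a ring. Among the measured compounds shown here, no measured step tests the added chain carbon. The nearest comparison is the change at the carbonyl, a 1.6-fold higher number from compound 2 to compound 3 (0.20 log units; within the scatter), which stayed within the scatter. A step of about a 1.2-fold lower number from compound 3 to compound 4 (0.07 log units; within the scatter) is therefore expected, in no direction beyond the scatter. Compound 4 is estimated at 500 nM, in a range from 200 nM to 1300 nM.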

Compound 4, half-maximal inhibitory concentration: 805 nM
Estimate against measurement, compound 4: 1.6-fold (0.21 log units) below; measured number inside the range.
By their numbers in this assay, from the lowest: compounds 2, 3, 4 and 1 (each within the scatter of the next, the first and the last beyond it).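

Swapping 1-acetylpiperidin-4-yl for the larger (1-propanoylpiperidin-4-yl)methyl gives a 1.4-fold higher number from compound 3 to compound 4 (0.13 log units; within the scatter) so this position accepts the added chain carbon and the longer acyl group together without a clear loss. The ethoxycarbonyl group keeps a real edge over the new group, with a 2.1-fold higher number from compound 2 to compound 4 (0.33 log units; beyond the scatter) and the new group does not clearly separate from the triazole side chain, with a 1.6-fold lower number from compound 1 to compound 4 (0.20 log units; within the scatter) as its step.

From the compounds shown here alone, these compounds do not separate the effect of the added chain carbon from that of the propanoyl group, and a free amine on the piperidine or a longer chain remains open. No evidence here gives a cause for any of these steps.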